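Swapping Chloro for Bromo on a Sugar Ring

This account rests on a few compounds, and the source may have more. Where it says the series, first, only, none or still open, it means among the compounds named here.

In a functional assay on P815 cells (Mus musculus) for antiproliferative activity (on this read-out lower numbers stand for stronger inhibition and higher numbers for weaker inhibition), two compounds have been tested so far, and neither produced a number. Compound 1, `Nc1ccn(C2OC(CO)C(Br)C2O)c(=O)n1`, stopped at > 100 ug/mL, which is a limit of the test rather than a measured value. Compound 2, `Nc1nc(=O)n(C2OC(CO)C(Cl)C2O)cc1F`, reached only > 30 ug/mL, again a limit and not a number. Compound 2 therefore stands at the edge of what this assay can report, at the limit of > 30 ug/mL in this assay, at which 1 of the 2 values shown sits, and compound 1 sits at the other edge, (the limit of > 100 ug/mL in this assay, at which 1 of the 2 values shown sits), so nothing beyond the usual scatter separates these two results.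

Compound 3, `Nc1nc(=O)n(C2OC(CO)C(Br)C2O)cc1F`, differs from compound 2 in a single place: bromo in place of chloro on a saturated ring carbon. Compound 1 already carries a bromo group on a saturated ring carbon of the same five-membered ring, and it gave only a limit in this assay. The step that the limit leaves unreadable from compound 2 to compound 3 is expected to be none beyond the scatter, with no clear direction. Compound 3 is estimated at 100 ug/mL, within a range from 30 ug/mL to 300 ug/mL, and most likely this assay will again report only a limit for it.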

Compound 3, concentration for 50% inhibition: 5 ug/mL
For compound 3 the middle estimate is 20-fold (1.30 log units) above the measured one; the measured number lies below the stated range.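

Bromo in place of chloro on a saturated ring carbon gives an at least 6.0-fold lower number from compound 2 to compound 3 (0.77 log units; beyond the scatter), so in this assay this position is not indifferent to which of the two halogens it carries. Bromo on that carbon is still not enough by itself, as fluoro in place of hydrogen on an aromatic carbon gives an at least 20-fold lower number from compound 1 to compound 3 (1.30 log units; beyond the scatter), and only the compound carrying both groups, compound 3, yields a real number here. The step from the chloro compound gives only a lower bound on the size of the change because compound 2 produced a limit rather than a number: the limit of > 30 ug/mL in this assay, at which 1 of the 3 values shown sits.

Going by these compounds, what lies behind the gap between chloro and bromo stays open, as does the true size of that gap, and two compounds sharing one change cannot show whether the same preference would hold on a different core. Nor do the compounds shown tell whether a larger halogen such as iodo, or an amine, on the same ring carbon would do as well as bromo, or whether a methyl group could take the place of fluoro on the aromatic carbon.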